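This account rests on a few compounds, and the source may have more. Where it says the series, first, only, none or still open, it means among the compounds named here.

Measured compounds:

compound 1, `COc1ccc(C(=O)/C=C\Nc2ccc(-c3nc4cc(OC)c(OC)c(OC)c4s3)cc2C)cc1O`, 11400 nM in a functional assay on HeLa cells (Homo sapiens) for antiproliferative activity, read by sulforhodamine B assay, with a stated time of 48 h; a lower number here means a stronger inhibitor, a higher number a weaker inhibitor;
compound 2, `COc1ccc2nc(-c3ccc(N/C=C\C(=O)c4ccc(OC)c(O)c4)c(C)c3)sc2c1`, 12000 nM in this assay;
compound 3, `COc1ccc(C(=O)/C=C\Nc2ccc(-c3nc4cc(OC)c(OC)c(OC)c4s3)cc2)cc1O`, 14100 nM in this assay.

Going by the values given here, all three numbers sit close together, and none of the gaps among them reaches beyond the usual scatter of this kind of measurement, so no compound can be called stronger or weaker than another. Compound 1 and compound 3 share a core and differ only in one change, (hydrogen in place of methyl on an aromatic carbon); that change gave a 1.2-fold higher number from compound 1 to compound 3 (0.09 log units; within the scatter). Compound 2 is built on a different core; how the two cores differ is not broken down here.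

Compound 4, `COc1ccc2nc(-c3ccc(N/C=C\C(=O)c4ccc(OC)c(O)c4)cc3)sc2c1`, has not yet been measured in this assay. Among the compounds with values here, it differs from compound 2 by hydrogen in place of methyl on an aromatic carbon, which is the same change as the one from compound 1 to compound 3. Because that earlier step was a 1.2-fold higher number from compound 1 to compound 3 (0.09 log units; within the scatter), the step in this assay from compound 2 to compound 4 is expected to be about as small, near a 1.1-fold higher number from compound 2 to compound 4 (0.05 log units; within the scatter). On that basis compound 4 is estimated at 13500 nM, with a likely range from 8000 nM to 24000 nM.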

Compound 4, half-maximal inhibitory concentration: 6900 nM
Compound 4: the middle estimate sits 2.0-fold (0.29 log units) above what was measured; the measured number lies below the stated range.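

Replacing the methyl with hydrogen on the core of compound 2 gave a 1.7-fold lower number from compound 2 to compound 4 (0.24 log units; within the scatter) in this assay, so compound 2 and compound 4 cannot be told apart in this measurement. Set beside the same change on the other core, this step does not differ from the earlier one by more than repeated measurements allow: the same change on two cores in this assay, a 1.2-fold higher number (0.09 log units; within the scatter) from compound 1 to compound 3 and a 1.7-fold lower number (0.24 log units; within the scatter) from compound 2 to compound 4, 2.2-fold (0.33 log units) apart, within the scatter of two such steps. This shows that the change produced no readable effect on either core and that these four compounds give no sign of the two cores responding differently, but it does not prove that the cores respond identically, as a small real difference could be hidden within the scatter.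

Going by these compounds, it remains open whether a different group at this place, such as an ethyl, a chlorine or an amine, would move the number beyond the scatter. On these data alone, it is also open how the number would respond if an amine or a carboxylic acid replaced the hydroxyl group that all four compounds share.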